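This account rests on a few compounds, and the source may have more. Where it says the series, first, only, none or still open, it means among the compounds named here.

Compounds measured in an assay on NK92 cells for inhibition of interleukin-2 (Homo sapiens), read by AlphaScreen, with stated times of 30 min and 1 h; a lower number here means a stronger inhibitor, a higher number a weaker inhibitor:
Compound 1 `Cn1c(Cc2nn(C)c(=O)c3ccccc23)nnc1SCC(=O)Nc1ccc(Cl)cc1Cl` gives 7700 nM.
Compound 2 `Cn1nc(Cc2nnc(SCC(=O)Nc3ccc(Cl)cc3Cl)n2CCC=O)c2ccccc2c1=O` gives 8600 nM.
Compound 3 `Cn1nc(Cc2nnc(SCC(=O)Nc3ccc(Cl)cc3Cl)n2CCCO)c2ccccc2c1=O` gives > 30000 nM, which is a limit of this assay and not a number.

Among the two numbers in this assay, compound 1 has the lowest, and the nearest to it is compound 2, whose step a 1.1-fold higher number from compound 1 to compound 2 (0.05 log units; within the scatter) lies within the scatter. The hydroxy compounds tell the other side of the picture: the steps of an at least 3.8-fold higher number from compound 1 to compound 3 (0.59 log units; beyond the scatter) and an at least 3.4-fold higher number from compound 2 to compound 3 (0.54 log units; beyond the scatter) both reach beyond the scatter, though the value of compound 3 sits at the limit of > 30000 nM in this assay, at which 1 of the 3 values shown sits.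

Compound 4 `Cn1c(Cc2nn(CCC=O)c(=O)c3ccccc23)nnc1SCC(=O)Nc1ccc(Cl)cc1Cl` has not yet been measured. It differs from compound 1 in this way: formylmethyl in place of hydrogen on a saturated chain carbon bound to an aromatic nitrogen. The measured step that bears on it most directly is a 1.1-fold higher number from compound 1 to compound 2 (0.05 log units; within the scatter), where the same group enters at a saturated chain carbon bound to an aromatic nitrogen elsewhere in the shared core and leaves the number where it was. The hydroxy steps to compound 3 involve a different group and do not bear on a formylmethyl. Compound 4 is therefore expected to give a number close to that of compound 1, with a step of a 1.1-fold higher number from compound 1 to compound 4 (0.04 log units; within the scatter) expected in this assay. The estimate for compound 4 is 8500 nM, expected to fall between 4000 nM and 20000 nM.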

Compound 4, half-maximal inhibitory concentration: > 30000 nM
Compound 4: no number, only a limit (the forecaster's own chance of this, stated with the estimate: 15%); at least 3.5-fold (0.54 log units) between middle value and limit.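

In this assay the formylmethyl change at this position is not neutral: it gives an at least 3.8-fold higher number from compound 1 to compound 4 (0.59 log units; beyond the scatter), whereas the same change elsewhere in the shared core gives a 1.1-fold higher number from compound 1 to compound 2 (0.05 log units; within the scatter). The outcome of adding this group to a saturated chain carbon bound to an aromatic nitrogen therefore depends on which such carbon carries it, something compound 2 alone could not show, and a formyl-bearing chain is no longer tied to a number near that of compound 1. Compound 4 gives > 30000 nM, which is a limit of the assay and not a number, so the full size of the step cannot be read, and this limit now accounts for a larger share of the set: the limit of > 30000 nM in this assay, at which 2 of the 4 values shown sit.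

The compounds shown do not tell whether the formyl or the chain itself goes with the higher number at this position, a question that a plain propyl chain there would address. They also leave open how an amine or a carboxylic acid in place of the formyl would read in this assay.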